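From Alkenyl to Isobutyl on the Shared Core

A few compounds are considered here, and "the series" means these few. Any claim that something is new, unique, unknown or untested is made for them only; others in the source may bear on it.

In a functional assay on the whole organism with Mus musculus as the target (a higher number here means that more compound is needed for the effect, a lower number that less compound is needed), compound 1 `Cc1cc2c(c(C)c1N)CC(C)(C)O2` gives 16.3 mg/kg. Compound 2 `Cc1c(N)c(C)c2c(c1CN1CCCCC1)OC(C)(C)C2` reaches only a limit, > 50 mg/kg. Compound 3 `CC(C)=Cc1c(C)c(N)c(C)c2c1OC(C)(C)C2` gives 21.9 mg/kg, which lies within the scatter of compound 1, and the data show an at least 2.2-fold lower number from compound 2 to compound 3 (0.35 log units; beyond the scatter).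

Compound 4 `Cc1c(N)c(C)c2c(c1CC(C)C)OC(C)(C)C2` carries isobutyl in place of 2-methylprop-1-en-1-yl on an aromatic carbon. For the measured compounds named here, two measured steps bear on this carbon: adding 2-methylprop-1-en-1-yl gave a 1.3-fold higher number from compound 1 to compound 3 (0.13 log units; within the scatter), while adding (piperidin-1-yl)methyl gave an at least 3.0-fold higher number from compound 1 to compound 2 (0.48 log units; beyond the scatter). Isobutyl resembles the first group far more than the second, so no shift beyond the scatter is expected. The expected step is a 1.0-fold higher number from compound 3 to compound 4 (0.00 log units; within the scatter). For compound 4, the estimate is 22 mg/kg, with an expected range of 10 mg/kg to 48 mg/kg.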

Compound 4, dose for 50% inhibition: 13.3 mg/kg
The estimate for compound 4 lay 1.7-fold (0.22 log units) above the measured number, within the range that was stated.
By their numbers in this assay, from the lowest: compounds 4, 1 and 3 (each within the scatter of the next). At a limit, above all of these: compound 2.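

In this assay, removing the double bond outside the aromatic ring changes nothing that can be told apart, with a 1.6-fold lower number from compound 3 to compound 4 (0.22 log units; within the scatter), and placing isobutyl on the aromatic carbon of the shared core gives a 1.2-fold lower number from compound 1 to compound 4 (0.09 log units; within the scatter). This saturated chain thus joins 2-methylprop-1-en-1-yl as tolerated here, whereas replacing piperidin-1-yl with isopropyl on the saturated chain carbon gives an at least 3.7-fold lower number from compound 2 to compound 4 (0.57 log units; beyond the scatter). That step rests on a limit for compound 2, not a number: the limit of > 50 mg/kg in this assay, at which 1 of the 4 values shown sits.

On these data alone, what a longer chain or a cyclohexylmethyl group would do at this carbon remains open. So does whether the ring or the nitrogen of piperidin-1-yl separates compound 2 from compound 4.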